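Aminopyrimidine efficacy: swapping the aryl group on the anilino nitrogen

This account rests on a few compounds, and the source may have more. Where it says the series, first, only, none or still open, it means among the compounds named here.

Measured compounds:
Compound 1, `COc1c(Nc2ccc(S(C)(=O)=O)cc2F)ncnc1OC1C[C@@H]2COC[C@@H](C1)N2C(=O)OC1(C)CC1`: 79%
Compound 2, `CC1(OC(=O)N2C[C@H]3COC[C@@H](C2)[C@@H]3Oc2ncnc(Nc3ccc(C#N)cc3Cl)c2F)CC1`: 99%
Compound 3, `CC1(COC(=O)N2CC3COCC(C2)C3Oc2ncnc(Nc3ccc(C#N)cc3Cl)c2F)COC1`: 46%

Of the compounds shown here, three have been measured in a functional assay for agonist activity at Glucose-dependent insulinotropic receptor (Mus musculus), read by cAMP accumulation; a lower number here means a smaller maximal response, a higher number a larger maximal response. Compound 2 gives 99% in this assay, the highest of the three maximal responses. Compound 1 gives 79%, which lies beyond the usual scatter below the value of compound 2, and compound 3 gives 46%, the lowest of the three and furthest from compound 2. No two of these compounds differ in only one place, so none of the gaps between them can be tied to a single structural change.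

Compound 4, `CC1(OC(=O)N2C[C@H]3COC[C@@H](C2)[C@@H]3Oc2ncnc(Nc3ccccc3F)c2F)CC1`, has not yet been measured. It differs from compound 2 in one place: 2-fluorophenyl in place of 2-chloro-4-cyanophenyl on a nitrogen on an aromatic ring. For the measured compounds named here, no measured pair shows this kind of change. Since the shared core of compound 2 and compound 4 carries the highest value seen here, compound 4 is expected to retain a substantial maximal response, though a moderate decrease below compound 2 is the more likely direction, an expected step of a number 19 percentage points lower from compound 2 to compound 4 (beyond the scatter). Compound 4 is therefore estimated at 80%, with a range from 55% to 100%.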

Compound 4, largest response reached (reported as percent of maximum), in percent of the reference or control that the assay uses: 76%
The estimate for compound 4 lay 4 percentage points above the measured number; low and high end bracket the measured number.
By their numbers in this assay, from the lowest: compound 3; then compounds 4 and 1 (each within the scatter of the next); then compound 2.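

In this assay, for the compounds shown here, 2-fluorophenyl in place of 2-chloro-4-cyanophenyl on a nitrogen on an aromatic ring gives a number 23 percentage points lower from compound 2 to compound 4 (beyond the scatter) and provides the first reading of a single change. The response falls but is not lost: compound 4 gives 76% and so shows that, on this core, neither the chlorine nor the nitrile of compound 2 is needed for a sizeable maximal response. Nothing available explains why the response falls with this change.

The chlorine, the nitrile and the fluorine all change in this one step, so the pair cannot divide the drop among them. From the compounds shown here alone, how a plain phenyl or a pyridyl group on the same nitrogen would compare, and whether this change would act alike on the cores of compound 1 or compound 3, remains open.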